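Exchanging Chloro and Cyano Positions on the Aryl Ring

The source may hold more compounds than are shown below. What is called first, only, known or untested is meant among the compounds shown, and "the series" means these compounds.

Compound 1 `CC/C(=C(/c1ccc(/C=C/C(=O)O)cc1)c1cc2ccccc2[nH]1)c1ccccc1OC(F)(F)F`: 206 nM
Compound 2 `CC/C(=C(/c1ccc(/C=C/C(=O)O)cc1)c1cc2ccccc2[nH]1)c1ccc(Cl)cc1Cl`: 11 nM
Compound 3 `CC/C(=C(/c1ccc(/C=C/C(=O)O)cc1)c1cc2ccccc2[nH]1)c1ccc(C#N)cc1Cl`: 49 nM

In a functional assay on MCF7 cells (Homo sapiens) for inhibition (a lower number here means a stronger inhibitor, a higher number a weaker inhibitor), compound 1 stands highest of the three numbers, with compound 3 nearest and compound 2 furthest. Compound 4 `CC/C(=C(/c1ccc(/C=C/C(=O)O)cc1)c1cc2ccccc2[nH]1)c1ccc(Cl)cc1C#N` differs from compound 1 in one place: 4-chloro-2-cyanophenyl in place of 2-(trifluoromethoxy)phenyl on a double-bonded chain carbon bound to a double-bonded chain carbon and a saturated chain carbon. Among the compounds with values here, two measured steps bear on this change. Placing 2,4-dichlorophenyl on the same carbon gave a 19-fold lower number from compound 1 to compound 2 (1.27 log units; beyond the scatter), and placing 2-chloro-4-cyanophenyl there gave a 4.2-fold lower number from compound 1 to compound 3 (0.62 log units; beyond the scatter); within that pair, cyano in place of chloro on an aromatic carbon gave a 4.5-fold higher number from compound 2 to compound 3 (0.65 log units; beyond the scatter). Compound 4 carries chloro and cyano like compound 3, but as 4-chloro-2-cyanophenyl, so a drop between those two outcomes seems likely. Compound 4 is therefore expected to show an 8.2-fold lower number from compound 1 to compound 4 (0.92 log units; beyond the scatter), an estimated 25 nM with a range of 8 nM to 80 nM.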

Compound 4, half-maximal inhibitory concentration: 14 nM
Beside the measured number, compound 4's estimate is 1.8-fold (0.25 log units) above it; the range from low to high includes it.
By their numbers in this assay, from the lowest: compounds 2 and 4 (each within the scatter of the next); then compound 3; then compound 1.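

In this assay, 4-chloro-2-cyanophenyl in place of 2-chloro-4-cyanophenyl gives a 3.5-fold lower number from compound 3 to compound 4 (0.54 log units; beyond the scatter), so the cost of a cyano group seen earlier depends on where it sits on this ring. Cyano in place of chloro now gives a 1.3-fold higher number from compound 2 to compound 4 (0.10 log units; within the scatter), and the change from the 2-(trifluoromethoxy)phenyl compound gives a 15-fold lower number from compound 1 to compound 4 (1.17 log units; beyond the scatter). Going by these compounds, whether a methyl or methoxy group could stand in for the chloro of compound 4 and hold this number stays open. No measurement shown explains why the two arrangements of chloro and cyano differ.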